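Swapping a carboxy group for a dichlorophenyl on a coumarin-type core

The source may hold more compounds than are shown below. What is called first, only, known or untested is meant among the compounds shown, and "the series" means these compounds.

Measured so far:
compound 1, `Cc1cc(=O)oc2cc(OCCCn3cc(CNC(=O)CCCCC4CCSS4)nn3)ccc12` — 69.4%
compound 2, `O=C(CCCCC1CCSS1)NCc1cn(CCCOc2ccc3cc(C(=O)O)c(=O)oc3c2)nn1` — 59.9%

Of the compounds shown here, two have been tested in a functional assay on PC-12 cells (Rattus norvegicus) for cytotoxicity, read by MTT assay, with stated times of 3 h and 2 h, tested at 10 uM; a higher number here means a stronger effect of the compound at the concentration tested, a lower number a weaker effect. In this assay compound 1 gives 69.4% and compound 2 gives 59.9%. Compound 2 has the lower of the two numbers, but the gap to compound 1 lies within the usual scatter of repeated measurements, so the two are best read as showing about the same effect.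

The next compound, compound 3, `O=C(CCCCC1CCSS1)NCc1cn(CCCOc2ccc3cc(-c4ccc(Cl)c(Cl)c4)c(=O)oc3c2)nn1`, differs from compound 2 in one place: 3,4-dichlorophenyl in place of carboxy on an aromatic carbon. Within the data shown here, no pair of measured compounds shows what a change of this kind does here, so the expectation for compound 3 rests on the values of compound 1 and compound 2 alone, which both sit in the same region. The step from compound 2 to compound 3 is expected to be small, either direction, and most likely not beyond the scatter: a number 4.1 percentage points higher from compound 2 to compound 3 (within the scatter). For compound 3 the estimate in this assay is 64%, with a range from 45% to 83%.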

Compound 3, a percentage reported as activity, at one concentration (the size of the read-out at that concentration, not a potency): 49.6%
Estimate against measurement, compound 3: 14.4 percentage points above, and the stated range covers the measured number.
By their numbers in this assay, from the lowest: compound 3; then compounds 2 and 1 (each within the scatter of the next).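

Among these compounds, replacing carboxy with 3,4-dichlorophenyl on this aromatic carbon gives, in this assay, a number 10.3 percentage points lower from compound 2 to compound 3 (beyond the scatter), the first step at this position that can be read. It shows that the read-out responds to what sits on this carbon, although the step is modest and the compound with the large aryl group keeps a clear effect at the single concentration tested. The swap takes away one hydrogen-bond donor and one hydrogen-bond acceptor and brings in a six-membered aromatic ring with two chlorines, but no measurement shown here says which of these differences accounts for the step.

The compounds shown leave open whether the ring itself or its two chlorines matter more, since a plain phenyl or a 4-chlorophenyl on this carbon would separate the two. They also leave open how a small group without a ring, such as an amine or a methyl ester, would compare with carboxy at this position, and so whether the read-out follows the size of the group or something else about it.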